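A few compounds are considered here, and "the series" means these few. Any claim that something is new, unique, unknown or untested is made for them only; others in the source may bear on it.

Of the compounds shown here, three built on one shared core have been measured in a functional assay on MDA-MB-231 cells (Homo sapiens) for cytotoxicity, read by MTT assay, with a stated time of 72 h; a lower number here means a stronger inhibitor, a higher number a weaker inhibitor. Compound 1 `COc1ccc(/C=N/NC(=O)Nc2ccc(Oc3ccnc4cc(OCCCN5CCCCC5)c(OC)cc34)c(F)c2)cc1` gives 840 nM in this assay. Compound 2 `COc1cc2c(Oc3ccc(NC(=O)N/N=C/c4ccc(Cl)cc4Cl)cc3F)ccnc2cc1OCCCN1CCCCC1` gives 750 nM in this assay, and compound 3 `COc1ccc(/C=N/NC(=O)Nc2ccc(Oc3ccnc4cc(OCCCN5CCC(C)CC5)c(OC)cc34)c(F)c2)cc1` gives 1000 nM in this assay. Compound 3 carries the highest of the three numbers, yet the gaps to the others are small enough to count as scatter; the step to it reads a 1.2-fold higher number from compound 1 to compound 3 (0.08 log units; within the scatter). The still unmeasured compound 4 `COc1cc2c(Oc3ccc(NC(=O)N/N=C/c4ccc(Cl)cc4Cl)cc3F)ccnc2cc1OCCCN1CCC(C)CC1` differs from compound 3 in a single place: 2,4-dichlorophenyl in place of 4-methoxyphenyl on a carbon with a double bond to nitrogen. The same exchange has already been seen once in this set, where it produced a 1.1-fold lower number from compound 1 to compound 2 (0.05 log units; within the scatter), a shift that stays inside the scatter. On that basis the change in this assay is expected to be small and, if anything, slightly downward: a 1.1-fold lower number from compound 3 to compound 4 (0.05 log units; within the scatter). Compound 4 is therefore estimated at 900 nM in this assay, with a range from 450 nM to 1800 nM.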

Compound 4, half-maximal inhibitory concentration: 910 nM
Compound 4: the middle estimate sits 1.0-fold (0.00 log units) below what was measured, within the range that was stated.
By their numbers in this assay, from the lowest: compounds 2, 1, 4 and 3 (each within the scatter of the next).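

In this assay, the exchange of 4-methoxyphenyl for 2,4-dichlorophenyl on a carbon with a double bond to nitrogen now appears on a second core, giving a 1.1-fold lower number from compound 3 to compound 4 (0.04 log units; within the scatter), and the two readings agree: the same change on two cores in this assay, a 1.1-fold lower number (0.05 log units; within the scatter) from compound 1 to compound 2 and a 1.1-fold lower number (0.04 log units; within the scatter) from compound 3 to compound 4, 1.0-fold (0.01 log units) apart, within the scatter of two such steps. The methyl on a saturated ring carbon also repeats on a second core, giving a 1.2-fold higher number from compound 2 to compound 4 (0.08 log units; within the scatter), and again the two readings agree: the same change on two cores in this assay, a 1.2-fold higher number (0.08 log units; within the scatter) from compound 1 to compound 3 and a 1.2-fold higher number (0.08 log units; within the scatter) from compound 2 to compound 4, 1.0-fold (0.01 log units) apart, within the scatter of two such steps. Going by these compounds alone, each change therefore gives a matching small step whether or not the other is present, and no compound among the four goes against this.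

The compounds shown leave open whether a pyridyl or a 4-carboxyphenyl group on that carbon would move the number beyond the scatter. They also leave open whether a larger group than methyl on the saturated ring, such as a benzyl or a dimethylamino group, would do so.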